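Truncating the sulfur substituent: compound 2 to compound 4

The source may hold more compounds than are shown below. What is called first, only, known or untested is meant among the compounds shown, and "the series" means these compounds.

Three compounds of the series have numbers in a functional assay on PC-9 cells (Homo sapiens) for inhibition, read by MTT assay, with a stated time of 72 h; a lower number here means a stronger inhibitor, a higher number a weaker inhibitor. Compound 1 `Cc1cc(Nc2cc(-c3ccc(Cl)cc3)[nH]n2)n2nc(SCc3ccc(Br)cc3)nc2n1` gives 4920 nM. Compound 2 `Cc1cc(Nc2cc(-c3ccccc3)[nH]n2)n2nc(SCc3nc4ccccc4[nH]3)nc2n1` gives 4840 nM. Compound 3 `Cc1cc(Nc2cc(-c3ccc(F)cc3)[nH]n2)n2nc(SCc3ccc(Br)cc3)nc2n1` gives 6210 nM. For the measured compounds named here, the only measured single-point step, a 1.3-fold higher number from compound 1 to compound 3 (0.10 log units; within the scatter), sits on an aromatic carbon and stays within the scatter. Compound 2 has the lowest of the three numbers, yet its gap to compound 1 and to compound 3 is within the scatter, so the three stand together rather than in any order.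

Compound 4 `C=CCSc1nc2nc(C)cc(Nc3cc(-c4ccccc4)[nH]n3)n2n1` has not been measured. Relative to compound 2 the change is vinyl in place of 1H-benzimidazol-2-yl on a saturated chain carbon bound to a sulfur. Going by the values given here, none of the measured steps touches the group on the sulfur: all three measured compounds carry a ring-bearing group there, and the one step in hand, between compound 1 and compound 3, lies elsewhere. Among the compounds with values here, no measured step therefore bears on this change, and neither direction nor size can be read from the series. The working expectation is a number in the region of compound 2, with a wide range to cover the untested change at the sulfur. Compound 4 is expected to give 6500 nM in this assay, between 2500 nM and 17000 nM. The expected step is a 1.3-fold higher number from compound 2 to compound 4 (0.13 log units; within the scatter), not beyond the scatter.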

Compound 4, half-maximal inhibitory concentration: > 50000 nM
Compound 4: only a limit was reported; the forecaster's own chance of this, stated with the estimate: 15%; middle value at least 7.6-fold (0.88 log units) from the limit.
By their numbers in this assay, from the lowest: compounds 2, 1 and 3 (each within the scatter of the next). At a limit, above all of these: compound 4.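

The group on the sulfur now stands out as a position that matters in this assay: replacing ((1H-benzimidazol-2-yl)methyl)sulfanyl with allylsulfanyl gives a large change (an at least 10-fold higher number from compound 2 to compound 4 (1.01 log units; beyond the scatter)). For the compounds shown here, the earlier compounds could not show this, since all three carry a ring-bearing group on the sulfur and their numbers lie within the scatter of one another, as does the only earlier step, which sits on an aromatic carbon (a 1.3-fold higher number from compound 1 to compound 3 (0.10 log units; within the scatter)). The result for compound 4 is a limit and not a number, so the step gives only a minimum size and the true gap stays unknown: the limit of > 50000 nM in this assay, at which 1 of the 4 values shown sits.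

The compounds shown do not separate the loss of the rings from the loss of the hydrogen-bond donor and acceptor that leave with 1H-benzimidazol-2-yl, or from the shorter size of the group that enters. A plain benzyl, a longer alkyl chain or an amine on the sulfur chain would be needed to tell how much of the group is required, and compound 2 differs from compound 1 and compound 3 in more than one place, so the rings on the sulfur chain cannot be ranked against one another.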